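This account rests on a few compounds, and the source may have more. Where it says the series, first, only, none or still open, it means among the compounds named here.

In an ADME assay on microsomes from liver (Homo sapiens) for metabolic stability, read by LC-MS, using NADPH, with stated times of 5 min and 30 min, tested at 1 uM (on this read-out lower numbers stand for a less stable compound and higher numbers for a more stable compound), compound 2 (`O[C@@H](CCc1ccc(F)cc1)C[C@H](O)c1cc(-c2ccccc2)on1`) stands highest of the two measured compounds at 84% against compound 1 (`COc1ccc(CC[C@H](O)C[C@@H](O)c2cc(-c3ccccc3)on2)cc1`) at 32% on the same read-out, a gap beyond the scatter. Compound 3 (`COc1ccc(CC[C@H](O)C[C@H](O)c2cc(-c3ccccc3)on2)cc1`) has not yet been measured. Within the data shown here, it departs from compound 2 by methoxy in place of fluoro on an aromatic carbon as the single change: methoxy in place of fluoro on an aromatic carbon, para to a large group, so that 4-fluorophenyl becomes 4-methoxyphenyl. Among the measured compounds shown here, no step between measured compounds isolates this change. For the measured compounds named here, the only guide is compound 1, which also carries 4-methoxyphenyl and reads 32% on this scale, and one compound is thin evidence. In this assay a fall beyond the scatter is expected, estimated as a number 42 percentage points lower from compound 2 to compound 3 (beyond the scatter) for now. Compound 3 is expected at 42% with an estimated range of 20% to 68% on this read-out.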

Compound 3, percent of the compound remaining in the Homo sapiens assay: 33%
Compound 3: the middle estimate sits 9 percentage points above what was measured, within the range that was stated.
By their numbers in the Homo sapiens assay, from the lowest: compounds 1 and 3 (each within the scatter of the next); then compound 2.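

Among these compounds, in the Homo sapiens assay the change to 4-methoxyphenyl, para to a large group, gives a number 51 percentage points lower from compound 2 to compound 3 (beyond the scatter) as the first direct reading of this replacement. Among the compounds shown here, in the Homo sapiens assay inverting one stereocentre at a saturated chain carbon gives a number 1 percentage points higher from compound 1 to compound 3 (within the scatter) and the low reading with 4-methoxyphenyl thus holds for both configurations as drawn, on the single pair that tests it: the fact that compounds 1 and 3 differ only in the configuration as drawn. In a physicochemical assay for solubility, in phosphate buffer, measured as kinetic solubility, at pH 7.4 (on this read-out lower numbers stand for lower solubility and higher numbers for higher solubility), compound 2 gives 25000 nM and compound 3 gives 25000 nM. In the physicochemical assay the same methoxy for fluoro replacement gives no change at the digits printed from compound 2 to compound 3 (within the scatter) and the two read-outs part on this change.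

Going by these compounds, it remains open whether the fall in the Homo sapiens assay is specific to methoxy, or whether ethoxy, hydroxy or chloro at the same place would read alike. It also remains open whether the configuration at that chain carbon matters as little with 4-fluorophenyl, where only one configuration is shown.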